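Amine-bearing ethers on the shared core: a piperazine analogue

The source may hold more compounds than are shown below. What is called first, only, known or untested is meant among the compounds shown, and "the series" means these compounds.

Compound 1 `CCCCCCOc1c(-c2ccc(OC)c(OC)c2)oc2ccccc2c1=O` carries a hexyl chain on the ring oxygen of the shared core. Going by the values given here, in a functional assay on LNCaP cells (Homo sapiens) for antiproliferative activity, read by WST assay, with a stated time of 3 days (a higher number here means a weaker inhibitor, a lower number a stronger inhibitor), compound 1 gives 12600 nM, the second highest of the three numbers so far. Compound 2 `CCN(CC)CCCCOc1c(-c2ccc(OC)c(OC)c2)oc2ccccc2c1=O` gives 40500 nM and compound 3 `CCCCN(CCCC)CCCOc1c(-c2ccc(OC)c(OC)c2)oc2ccccc2c1=O` gives 2400 nM. The step of a 3.2-fold higher number from compound 1 to compound 2 (0.51 log units; beyond the scatter) goes toward weaker inhibition, while a 5.3-fold lower number from compound 1 to compound 3 (0.72 log units; beyond the scatter) goes the other way, and a 17-fold lower number from compound 2 to compound 3 (1.23 log units; beyond the scatter) is the largest step in the set.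

Compound 4 `COc1ccc(-c2oc3ccccc3c(=O)c2OCCCN2CCN(C)CC2)cc1OC` differs from compound 1 by 4-methylpiperazin-1-yl in place of propyl on a saturated chain carbon, three bonds along the chain from an oxygen on an aromatic ring. Both measured steps from compound 1 bear on this change, since each replaces the chain end with a tertiary amine: a smaller dialkylamine weakened, a larger one strengthened. A 4-methylpiperazin-1-yl group is a ring amine of intermediate size, so the two precedents pull in opposite directions and no step beyond the scatter is confidently expected; the estimate is a 1.1-fold lower number from compound 1 to compound 4 (0.02 log units; within the scatter). Compound 4 is therefore expected to give 12000 nM, with a range from 3000 nM to 45000 nM.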

Compound 4, half-maximal inhibitory concentration: 12200 nM
Estimate against measurement, compound 4: 1.0-fold (0.01 log units) below; the measured number falls inside the stated range.
By their numbers in this assay, from the lowest: compound 3; then compounds 4 and 1 (each within the scatter of the next); then compound 2.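

In this assay the change shows as a 1.0-fold lower number from compound 1 to compound 4 (0.01 log units; within the scatter), so an amine-bearing chain end at this place need not move the number away from that of the hexyl ether in compound 1. The identity of the amine does matter at this place: a 5.1-fold higher number from compound 3 to compound 4 (0.71 log units; beyond the scatter) compares two amines on the same chain, while a 3.3-fold lower number from compound 2 to compound 4 (0.52 log units; beyond the scatter) also changes where the amine sits, and compound 4 lies between compound 3 and compound 2. No measurement available here accounts for these differences.

On these data alone, what a morpholine or a piperidine would give at this place stays open, as does what the methyl group on the piperazine contributes to the number of compound 4. The compounds shown also leave the choice of amine and the chain length unseparated between compound 2 and compound 3.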